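The source may hold more compounds than are shown below. What is called first, only, known or untested is meant among the compounds shown, and "the series" means these compounds.

Measured compounds in an assay for displacement of a labelled ligand from Sigma non-opioid intracellular receptor 1 (Cavia porcellus), read by scintillation counting; a higher number here means a weaker inhibitor, a lower number a stronger inhibitor:
- compound 1, `NCC[C@@H]1CCO[C@H](c2ccccc2)O1`: 165 nM
- compound 2, `CNCC[C@@H]1CCO[C@H](c2ccccc2)O1`: 449 nM
- compound 3, `CC[C@@]1(c2ccccc2)OCC[C@@H](CCNC)O1`: 856 nM

Compound 2 stands second highest of the three numbers in this assay; its nearest neighbour is compound 3, a step up that lies within the scatter, and the furthest is compound 1, whose step a 2.7-fold higher number from compound 1 to compound 2 (0.43 log units; beyond the scatter) lies beyond it.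

Compound 4, `NCCC[C@@H]1CCO[C@H](c2ccccc2)O1`, is not yet measured. It differs from compound 2 by aminomethyl in place of methylamino on a saturated chain carbon, two bonds along the chain from a saturated ring carbon; the two share the same atoms, joined differently, so the methyl moves from the amine nitrogen into the chain, leaving a primary amine on a 3-aminopropyl chain.

Of the measured steps, a 2.7-fold higher number from compound 1 to compound 2 (0.43 log units; beyond the scatter) bears most directly, since it shows what methyl on the amine nitrogen did; removing it again should reverse part of that step. The step of a 1.9-fold higher number from compound 2 to compound 3 (0.28 log units; within the scatter) concerns a ring carbon and bears little. Among the measured compounds shown here, no measured step covers the longer chain by itself, so the expected lowering is tempered.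

For compound 4 in this assay the expected step is a 1.8-fold lower number from compound 2 to compound 4 (0.25 log units; within the scatter), giving an estimate of 250 nM with a range of 100 nM to 700 nM.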

Compound 4, inhibition constant: 167 nM
Estimate against measurement, compound 4: 1.5-fold (0.18 log units) above, and the stated range covers the measured number.
By their numbers in this assay, from the lowest: compounds 1 and 4 (each within the scatter of the next); then compounds 2 and 3 (each within the scatter of the next).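

In this assay, moving the methyl from the amine nitrogen into the chain, 2-(methylamino)ethyl to 3-aminopropyl, gives a 2.7-fold lower number from compound 2 to compound 4 (0.43 log units; beyond the scatter) and so separates the effect of the carbon's placement from that of its mere presence. The extra chain carbon on the primary amine gives a 1.0-fold higher number from compound 1 to compound 4 (0.01 log units; within the scatter) and leaves the two primary amines level, while the same carbon on the nitrogen carries the penalty seen in compound 2. At this position the series therefore tolerates the added carbon in the chain but not on the nitrogen, and no supporting measurement bears on why.

From the compounds shown here alone, whether a 4-aminobutyl chain stays level with compound 4 remains open. So does whether a 3-(methylamino)propyl chain repeats the nitrogen methyl penalty on the longer chain.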